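The source may hold more compounds than are shown below. What is called first, only, known or untested is meant among the compounds shown, and "the series" means these compounds.

Measured so far:
- compound 1, `O=C(Nc1ncc(C(Oc2ccc3cc(Br)ccc3c2)c2ccc(Cl)cc2)s1)c1ccccc1`, in an ADME assay on HepG2 2.2.15 cells (Homo sapiens) for cytotoxicity (a higher number here means that more compound is tolerated, a lower number that less compound is tolerated), compound 1 gives "not toxic" (no number reported).
- compound 2, `Cc1ccc(C)c(S(=O)(=O)Nc2ncc(C(Oc3ccc4cc(Br)ccc4c3)c3ccc(Cl)cc3)s2)c1`, in this assay compound 2 gives > 50000 nM, which is a limit of the assay and not a number.
- compound 3, `CCc1ccc(S(=O)(=O)Nc2ncc(C(Oc3ccc4cc(Br)ccc4c3)c3ccc(Cl)cc3)s2)cc1`, in this assay compound 3 gives > 50000 nM, also a limit of the assay and not a number.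

Compound 3 therefore stands at the edge of what this assay can report, where compound 2 also sits; compound 1 has no number at all. Among the compounds with values here, the only step that can be traced, a step that the two limits leave unreadable from compound 2 to compound 3, cannot be read in size, since both ends are limits (the limit of > 50000 nM in this assay, at which 2 of the 3 values shown sit). Compound 4, `O=S(=O)(Nc1ncc(C(Oc2ccc3cc(Br)ccc3c2)c2ccc(Cl)cc2)s1)c1ccc(Cl)nc1`, differs from compound 3 in that (6-chloropyridin-3-yl in place of 4-ethylphenyl on a sulfonyl sulfur). Within the data shown here, nothing among the measured compounds shows a readable step for any change on the sulfonyl sulfur, so no movement beyond the scatter is expected, and the most likely outcome is again a limit. The step from compound 3 to compound 4 is estimated as a number no higher from compound 3 to compound 4 (the limit leaves the size open). For compound 4 the expected value in this assay is 50000 nM, with a range from 20000 nM to 100000 nM.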

Compound 4, half-maximal cytotoxic concentration: "not toxic" (no number reported)
Nothing numeric was reported for compound 4, so the estimate cannot be set against anything.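

Between compound 3 and compound 4 no new step can be read: in this assay compound 3 carries only a limit and compound 4 carries no number. The compounds shown leave open at what concentration they harm the cells, and whether the group on the sulfonyl sulfur changes that.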